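A few compounds are considered here, and "the series" means these few. Any claim that something is new, unique, unknown or untested is made for them only; others in the source may bear on it.

Notes on the series. Compound 1 `CC(C)N1CCN(Cc2csc(N)c2C(=O)c2ccc(Cl)cc2)CC1` gives -1% in a functional assay on CHO cells with adenosine receptor A1 (Homo sapiens) as the target, read by cAMP accumulation and immunoassay, with a stated time of 6 min, tested at 0.01 uM; on this read-out higher numbers stand for a weaker effect at the one concentration tested and lower numbers for a stronger effect. Compound 2 `Nc1scc(CN2CCN(c3cc(Cl)cc(Cl)c3)CC2)c1C(=O)c1ccc(Cl)cc1` gives -1%, and compound 3 `Nc1scc(CN2CCN(c3cccc4ccccc34)CC2)c1C(=O)c1ccc(Cl)cc1` gives 8.7%. On these numbers compound 2 stands level with compound 1 at the digits given, the two together the lowest of the three numbers, with compound 3 the furthest, a number 9.7 percentage points higher from compound 2 to compound 3 (within the scatter), so all three lie within the scatter of one another. Compound 4 `Nc1scc(CN2CCN(c3cccc(F)c3F)CC2)c1C(=O)c1ccc(Cl)cc1` differs from compound 2 by 2,3-difluorophenyl in place of 3,5-dichlorophenyl on an amine nitrogen in a ring. Among the compounds with values here, the steps that bear on this place are no change at the digits printed from compound 1 to compound 2 (within the scatter) and a number 9.7 percentage points higher from compound 2 to compound 3 (within the scatter); both exchanges on the amine nitrogen in a ring left the read-out within the scatter. Therefore in this assay the expected step is none beyond the scatter: a number 3 percentage points higher from compound 2 to compound 4 (within the scatter). Compound 4 is estimated at 2%, in the range -10% to 14%.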

Compound 4, a percentage reported as activity, at one concentration (the size of the read-out at that concentration, not a potency): -13%
Estimate against measurement, compound 4: 15 percentage points above, outside the stated range (below it).
By their numbers in this assay, from the lowest: compound 4; then compounds 1, 2 and 3 (each within the scatter of the next).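

In this assay, the amine nitrogen in a ring no longer looks indifferent to exchange: 2,3-difluorophenyl gives a number 12 percentage points lower from compound 2 to compound 4 (beyond the scatter), along with a number 21.7 percentage points lower from compound 3 to compound 4 (beyond the scatter) and a number 12 percentage points lower from compound 1 to compound 4 (beyond the scatter). The step from compound 2 to compound 4 also shows that exchanging one dihalogenated phenyl group for another can move the read-out, with a lower number standing for a stronger effect. Nothing at hand accounts for these steps.

Open, as far as these compounds go, is whether the halogen or its placement carries the step; 2,3-dichlorophenyl or 3,5-difluorophenyl on the same nitrogen would separate the two.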